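Predicting a methyl-to-ethyl step on a weaker analogue

The compounds below may be only part of what the source reports. "The series", "measured", "known", "first", "only" and "open" are said of these compounds alone.

Compound 1 `CO[C@@]12CCN(C)C[C@H]1[C@H](c1ccc(Br)cc1)C(C#N)=C(N)O2` gives 7900 nM in a functional assay on trachea (Cavia porcellus); a lower number here means a stronger inhibitor, a higher number a weaker inhibitor. Compound 2 `CCN1CC[C@@]2(OC)OC(N)=C(C#N)[C@@H](c3ccc(Br)cc3)[C@@H]2C1` differs from it by methyl in place of hydrogen on a saturated chain carbon bound to an amine nitrogen in a ring and gives 13200 nM in this assay, a step of a 1.7-fold higher number from compound 1 to compound 2 (0.22 log units; within the scatter). Compound 3 `COc1ccc([C@@H]2C(C#N)=C(N)O[C@]3(OC)CCN(C)C[C@@H]23)cc1` carries a different core, differing from compound 1 by methoxy in place of bromo on an aromatic carbon; in this assay compound 3 gives 23100 nM, which is a 2.9-fold higher number from compound 1 to compound 3 (0.47 log units; beyond the scatter). Compound 4 `CCN1CC[C@@]2(OC)OC(N)=C(C#N)[C@@H](c3ccc(OC)cc3)[C@@H]2C1` is not yet measured; it differs from compound 3 by methyl in place of hydrogen on a saturated chain carbon bound to an amine nitrogen in a ring, the same change that led from compound 1 to compound 2. Because that earlier step was a 1.7-fold higher number from compound 1 to compound 2 (0.22 log units; within the scatter), the step from compound 3 to compound 4 is expected to be similar in size, around a 1.5-fold higher number from compound 3 to compound 4 (0.18 log units; within the scatter). On this basis compound 4 is estimated to give about 35000 nM in this assay, most likely between 15000 nM and 80000 nM.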

Compound 4, half-maximal inhibitory concentration: 25500 nM
Compound 4: middle estimate off by 1.4-fold (0.14 log units), on the high side, and the stated range covers the measured number.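

The methyl-to-ethyl change gives a 1.1-fold higher number from compound 3 to compound 4 (0.04 log units; within the scatter) in this assay, and it behaves alike on the two cores: the same change on two cores in this assay, a 1.7-fold higher number (0.22 log units; within the scatter) from compound 1 to compound 2 and a 1.1-fold higher number (0.04 log units; within the scatter) from compound 3 to compound 4, 1.5-fold (0.18 log units) apart, within the scatter of two such steps. Methoxy in place of bromo gives a 1.9-fold higher number from compound 2 to compound 4 (0.29 log units; within the scatter), and this change also carries over between the two cores: the same change on two cores in this assay, a 2.9-fold higher number (0.47 log units; beyond the scatter) from compound 1 to compound 3 and a 1.9-fold higher number (0.29 log units; within the scatter) from compound 2 to compound 4, 1.5-fold (0.18 log units) apart, within the scatter of two such steps. Among the compounds shown here, this shows that, for these four compounds, each change can be carried from one core to the other without a gap larger than the scatter, but with only two pairs per change it does not show that this holds on any other core. The compounds shown leave open what a longer chain such as propyl would do at the same place. They also leave open whether a chloro group or a hydroxyl group in place of bromo would carry over as methoxy does.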